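The source may hold more compounds than are shown below. What is called first, only, known or untested is meant among the compounds shown, and "the series" means these compounds.

Measured in a functional assay on MDA-MB-436 cells (Homo sapiens) for antiproliferative activity, read by MTT assay, with a stated time of 48 h; on this read-out higher numbers stand for weaker inhibition and lower numbers for stronger inhibition:
compound 1 `CN1CCN(c2ccc(-c3cc4c(N5CCN(S(=O)(=O)N6CCCCC6)CC5)ncnc4s3)cc2)CC1` gives 7570 nM here
compound 2 `CN1CCN(c2ccc(-c3cc4c(N5CCN(S(=O)(=O)C6CC6)CC5)ncnc4s3)cc2)CC1` gives 10600 nM here
compound 3 `CN1CCN(c2ccc(-c3cc4c(N5CCN(C(=O)Nc6ccc(Cl)cc6)CC5)ncnc4s3)cc2)CC1` gives 9270 nM here

Compound 3, at 9270 nM, cannot be separated from either of the other two compounds. The measured steps around it are a 1.2-fold higher number from compound 1 to compound 3 (0.09 log units; within the scatter) and a 1.1-fold lower number from compound 2 to compound 3 (0.06 log units; within the scatter), and the remaining step is a 1.4-fold higher number from compound 1 to compound 2 (0.15 log units; within the scatter). All three lie within the scatter, so these numbers give no ranking.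

Compound 4 `CN1CCN(c2ccc(-c3cc4c(N5CCN(C(=O)Nc6cc(C(F)(F)F)ccc6F)CC5)ncnc4s3)cc2)CC1` differs from compound 3 in one place: 2-fluoro-5-(trifluoromethyl)phenyl in place of 4-chlorophenyl on an amide-type nitrogen. In words, this is 2-fluoro-5-(trifluoromethyl)phenyl in place of 4-chlorophenyl on an amide-type nitrogen. Among the measured compounds shown here, no measured step varies the group on that nitrogen, so direct evidence is lacking. The closest guide is the exchange of the whole group on the ring nitrogen, seen in a 1.2-fold higher number from compound 1 to compound 3 (0.09 log units; within the scatter) and a 1.1-fold lower number from compound 2 to compound 3 (0.06 log units; within the scatter). From the compounds shown here alone, neither exchange goes beyond the scatter, and the present change is smaller in kind, though a substituent swap on this aryl group remains untested.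

In this assay the expected result is a 1.2-fold lower number from compound 3 to compound 4 (0.06 log units; within the scatter), which means no expected step beyond the scatter.

For compound 4 the estimated value is 8000 nM with an expected range of 3500 nM to 16000 nM as the likely span.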

Compound 4, half-maximal inhibitory concentration: 8840 nM
For compound 4 the middle estimate is 1.1-fold (0.04 log units) below the measured one; the measured number falls inside the stated range.
By their numbers in this assay, from the lowest: compounds 1, 4, 3 and 2 (each within the scatter of the next).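

In this assay, among the compounds shown here, the earlier compounds exchanged the whole group on the amine nitrogen in a ring, whereas this is the first step that changes only the aryl group on the amide-type nitrogen: a 1.0-fold lower number from compound 3 to compound 4 (0.02 log units; within the scatter). The number stays within the scatter with 11 heavy atoms entering and 7 leaving, and with fluorine and trifluoromethyl in place of chlorine, so in these two compounds neither the larger group nor the different halogen substitution separates from the 4-chlorophenyl group on this read-out. No measured property bears on this result, so the flat step stands as an observation without an explanation.

The compounds shown leave open whether any group on the amide-type nitrogen can move the number beyond the scatter, for example an aryl group carrying a carboxylic acid or a dimethylamino group, or a longer alkyl chain in place of the aryl group. From the compounds shown here alone, it also remains open whether changes elsewhere on the shared core would do so, since all four compounds keep that part constant.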